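The source may report more compounds than this note shows. Statements on the series, on what has been measured and on what is new or still open speak of the compounds shown alone.

Measured so far in a functional assay on MKN-74 cells (Homo sapiens) for antiproliferative activity, with a stated time of 24 h; on this read-out higher numbers stand for weaker inhibition and lower numbers for stronger inhibition:
Compound 1 `NC(=O)c1c(NC(=O)c2ccccc2)sc2c1CCN(C(=S)Nc1ccccc1Cl)C2`: in this assay compound 1 gives 11800 nM.
Compound 2 `NC(=O)c1c(NC(=O)c2ccccc2C(F)(F)F)sc2c1CCN(C(=S)Nc1ccccc1Cl)C2`: in this assay compound 2 gives 21900 nM.
Compound 3 `Cc1ccccc1C(=O)Nc1sc2c(c1C(N)=O)CCN(C(=S)Nc1ccccc1Cl)C2`: in this assay compound 3 gives 11000 nM.

Of these three, compound 2 has the highest number, but its distance to the others is small: a 1.9-fold higher number from compound 1 to compound 2 (0.27 log units; within the scatter), and a 2.0-fold lower number from compound 2 to compound 3 (0.30 log units; within the scatter), both within the scatter, so none of the three can be called weaker or stronger than another on this evidence. The step to be judged goes from compound 2 to compound 4 `NC(=O)c1c(NC(=O)c2ccccc2C(F)(F)F)sc2c1CCN(C(=S)Nc1ccccc1Br)C2`. The change is bromo in place of chloro on an aromatic carbon. Neither of the measured steps touches this part of the molecule; both alter the other aromatic ring, and both, together with a 1.1-fold lower number from compound 1 to compound 3 (0.03 log units; within the scatter), moved the number only within the scatter. Within the data shown here, there is thus no direct precedent here, only the observation that single-group swaps on the aromatic rings of this core have so far left the read-out essentially unchanged. A step of no size beyond the scatter is therefore expected, a 1.2-fold lower number from compound 2 to compound 4 (0.09 log units; within the scatter). Compound 4 is estimated at 18000 nM, within a range of 8000 nM to 45000 nM.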

Compound 4, half-maximal inhibitory concentration: 23900 nM
Estimate against measurement, compound 4: 1.3-fold (0.12 log units) below, within the range that was stated.
By their numbers in this assay, from the lowest: compounds 3, 1, 2 and 4 (each within the scatter of the next, the first and the last beyond it).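

Compound 4 is the first compound shown with a change on the 2-chlorophenyl group, and in this assay the swap to 2-bromophenyl gives a 1.1-fold higher number from compound 2 to compound 4 (0.04 log units; within the scatter), so this position now has a reading of its own. At this place, on an aromatic carbon ortho to a large group, bromo can stand in for chloro without a difference that can be read, at least while trifluoromethyl sits on the other aromatic ring. No measurement at hand bears on what lies behind this result.

From the compounds shown here alone, whether an amine, a methoxy group or plain hydrogen at the same place would also stay within the scatter remains open. Also open, going by these compounds, is whether the same swap would read alike on compound 1 or compound 3, which lack the trifluoromethyl group.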